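The source may hold more compounds than are shown below. What is called first, only, known or untested is meant among the compounds shown, and "the series" means these compounds.

Compound 3 `COc1ccccc1Oc1ccc2c(NCCCNCc3cccc(OC)c3O)ccnc2c1` holds the highest solubility of the three measured compounds. In a physicochemical assay for solubility, with a stated time of 18 h, at pH 7.4 (on this read-out higher numbers stand for higher solubility and lower numbers for lower solubility), compound 3 gives 14500 nM. Compound 1 `COc1ccc(F)cc1CNCCCNc1ccnc2cc(CCC(C)C)ccc12` gives 4200 nM in this assay, and compound 2 `COc1ccc(F)cc1CNCCCNc1ccnc2cc(Cc3ccc(F)cc3)ccc12` gives 4200 nM; each of these two numbers sits well below that of compound 3, beyond the scatter.

Compound 4 `COc1ccc(F)cc1CNCCCNc1ccnc2cc(Oc3ccccc3OC)ccc12` has not yet been measured. It differs from compound 3 in one place: 5-fluoro-2-methoxyphenyl in place of 2-hydroxy-3-methoxyphenyl on a saturated chain carbon bound to an amine nitrogen. The group that enters, 5-fluoro-2-methoxyphenyl on a saturated chain carbon bound to an amine nitrogen, is the same one that compounds 1 and 2 carry, while the other end of compound 4 matches compound 3.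

For the measured compounds named here, only one measured step exists, no change at the digits printed from compound 1 to compound 2 (within the scatter), and it concerns a different part of the structure, so it gives no direct guide to the present change. The values do show that the two compounds bearing the entering group sit lower than compound 3. The estimate for compound 4 therefore expects a drop in this assay, a 2.2-fold lower number from compound 3 to compound 4 (0.35 log units; beyond the scatter), with wide uncertainty. Compound 4 is expected to give about 6500 nM, within a range from 2500 nM to 17000 nM.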

Compound 4, solubility: 14500 nM
Beside the measured number, compound 4's estimate is 2.2-fold (0.35 log units) below it, within the range that was stated.
By their numbers in this assay, from the lowest: compounds 1 and 2 (each within the scatter of the next); then compounds 3 and 4 (each within the scatter of the next).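

In this assay, the exchange at this position, on a saturated chain carbon bound to an amine nitrogen, gives no change at the digits printed from compound 3 to compound 4 (within the scatter) and so leaves the value unmoved, even though 2-hydroxy-3-methoxyphenyl and 5-fluoro-2-methoxyphenyl differ in their atoms and in their counts of hydrogen-bond donors and acceptors. The lower values of compounds 1 and 2 therefore cannot be pinned on 5-fluoro-2-methoxyphenyl, which compound 4 also carries; the gap follows the group on the aromatic carbon at the other end, with 2-methoxyphenoxy in place of 4-fluorobenzyl giving a 3.5-fold higher number from compound 2 to compound 4 (0.54 log units; beyond the scatter) and 2-methoxyphenoxy in place of isopentyl giving a 3.5-fold higher number from compound 1 to compound 4 (0.54 log units; beyond the scatter) in this same read-out. No supporting measurement is available to explain any of these results.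

On these data alone, the flat step rests on a single pair sharing 2-methoxyphenoxy, so it remains open whether the same exchange would also leave the value unmoved with isopentyl or 4-fluorobenzyl at the other end. Also open, as far as these compounds go, is how the value would respond if the aromatic group at this position gave way to a carboxylic acid or a longer chain.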